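A few compounds are considered here, and "the series" means these few. Any claim that something is new, unique, unknown or untested is made for them only; others in the source may bear on it.

Compound 1, `COC1=C(OC)[C@H](O)[C@H](C/C=C(\C)CC/C=C(\C)C[C@@H]2C[C@@H](C)C(=O)O2)[C@@H](C)C1=O`, compound 2, `COC1=C(OC)[C@H](O)[C@H](C/C=C(\C)CC/C=C(\C)C/C=C/C(C)(C)O)[C@@H](C)C1=O`, and compound 3, `COC1=C(OC)[C@H](OC(C)=O)[C@H](C/C=C(\C)CC/C=C(\C)C[C@H](O)C[C@@H](C)C(O)O)[C@@H](C)C1=O`, share one core and were examined in a functional assay on PC-3 cells (Homo sapiens) for inhibition, read by sulforhodamine B assay, with a stated time of 48 h; a lower number here means a stronger inhibitor of growth, a higher number a weaker inhibitor of growth. In this assay compound 1 reaches only the limit of the method, > 30000 nM. Compound 2 likewise gives no number in this assay, only the limit > 30000 nM. Compound 3 also stops at the limit, > 30000 nM. Where compound 2 stands is therefore known only as a limit, and the same holds for the two other values shown, since (the limit of > 30000 nM in this assay, at which 3 of the 3 values shown sit). Within the data shown here, the one step that can be drawn between these compounds, a step that the two limits leave unreadable from compound 1 to compound 2, is thus of unreadable size, and it concerns a different part of the chain from the change considered here.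

Compound 4, `COC1=C(OC)[C@H](O)[C@H](C/C=C(\C)CC/C=C(\C)CCCC(C)CO)[C@@H](C)C1=O`, remains to be measured. It differs from compound 2 by 3-(hydroxymethyl)butyl in place of 3-hydroxy-3-methylbut-1-en-1-yl on a saturated chain carbon bound to a double-bonded chain carbon. Among the measured compounds shown here, no measured step covers this exchange, and the single step available is unreadable, so no direction beyond the scatter can be taken from the data. Given that compound 2 sits at the limit > 30000 nM, compound 4 is expected to sit there as well, and the step that the limit leaves unreadable from compound 2 to compound 4 is expected to be indistinguishable from none. The estimate for compound 4 in this assay is 50000 nM, within 15000 nM to 200000 nM, most probably reported again only as a limit.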

Compound 4, concentration for 50% growth inhibition: > 30000 nM
Compound 4: only a limit was reported; the forecaster's own chance of this, stated with the estimate: 85%; the middle value is on the limit's open side.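

Compound 4, like compound 1, compound 2 and compound 3, gives no number in this assay, so neither the step from compound 2 to compound 4 nor that from compound 1 to compound 4 can be read: the limit of > 30000 nM in this assay, at which 4 of the 4 values shown sit. The compounds shown leave open whether these chain ends differ at all in this assay, as none of the four gives a number there.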